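The source may hold more compounds than are shown below. What is called first, only, known or untested is meant among the compounds shown, and "the series" means these compounds.

Measured so far:
- compound 1 `COc1ccc(C(=O)/C=C/c2cc(-c3cc(OC)c(OC)c(OC)c3)n3nc(-c4ccccc4)cc3n2)cc1` with 79800 nM
- compound 2 `COc1ccc(-c2cc(/C=C/C(=O)c3cc(OC)c(OC)c(OC)c3)nc3cc(-c4ccccc4)nn23)cc1OC` with 35000 nM
- compound 3 `COc1cc(-c2cc(C(=O)/C=C/c3ccccc3)nc3cc(-c4ccccc4)nn23)cc(OC)c1OC` with 44800 nM

In an ADME assay on HEK293 cells (Homo sapiens) for antiproliferative activity, read by MTT assay, with a stated time of 24 h (a lower number here means a stronger inhibitor, a higher number a weaker inhibitor), compound 2 gives 35000 nM, the lowest of the three numbers. Its nearest neighbour is compound 3, whose value sits within the scatter of repeated measurements; compound 1 lies beyond the scatter. The new compound 4 `COc1ccc(-c2cc(/C=C/C(=O)c3ccc(C)c(C)c3)nc3cc(-c4ccccc4)nn23)cc1OC` comes from compound 2 by one exchange: 3,4-dimethylphenyl in place of 3,4,5-trimethoxyphenyl on a carbonyl carbon. Within the data shown here, the only measured step that touches the aryl groups attached to the chain with the carbonyl is the one from compound 1 to compound 3, where a 1.8-fold lower number from compound 1 to compound 3 (0.25 log units; within the scatter). That step changed a different part of the molecule and did not move the number beyond the scatter, so it offers no direct guide to the new exchange. Among the measured compounds shown here, no measured pair shows a trimethoxyphenyl being replaced by a dimethylphenyl on the carbonyl carbon. With all three known values lying in a narrow band, the expectation for compound 4 in this assay is a step of a 1.1-fold higher number from compound 2 to compound 4 (0.06 log units; within the scatter), not beyond the scatter in either direction. Compound 4 is therefore estimated at 40000 nM, with a range from 15000 nM to 110000 nM.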

Compound 4, half-maximal inhibitory concentration: 46200 nM
Compound 4: the middle estimate sits 1.2-fold (0.06 log units) below what was measured; the measured number falls inside the stated range.
By their numbers in this assay, from the lowest: compounds 2, 3, 4 and 1 (each within the scatter of the next, the first and the last beyond it).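

In this assay, among these compounds, putting 3,4-dimethylphenyl in place of 3,4,5-trimethoxyphenyl on the carbonyl carbon gives a 1.3-fold higher number from compound 2 to compound 4 (0.12 log units; within the scatter), the first direct reading of a change at this position. The entering group has 8 heavy atoms and 0 hydrogen-bond acceptors, fewer on both counts than the group that leaves, so in this one pair a sizeable change in the group's make-up, including the loss of all its oxygen atoms, leaves the two numbers indistinguishable in this assay. Nothing available explains why the number holds at this position, and no independent measurement bears on the result.

Among the compounds shown here, the comparison covers only two groups at this place, both built on a six-membered aromatic ring of carbon only, so it remains open whether an amine, a carboxylic acid or a longer chain on that ring would also leave the number within the scatter. Going by these compounds, it also remains open whether this exchange would read the same way on a compound that differs from compound 2 elsewhere in the molecule.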